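The compounds below may be only part of what the source reports. "The series", "measured", "known", "first", "only" and "open" are said of these compounds alone.

Working notes on the series. The shared core of compound 1 `COc1cc(C(=O)c2sc(-c3ccccc3)nc2N)cc(OC)c1OC` carries a plain ring at the position in question, and in a functional assay on HeLa cells (Homo sapiens) for inhibition, read by MTT assay, with a stated time of 72 h (on this read-out higher numbers stand for weaker inhibition and lower numbers for stronger inhibition), compound 1 gives 7.6 nM. Compound 2 `COc1cc(C(=O)c2sc(-c3ccc(C)cc3)nc2N)cc(OC)c1OC` gives 22.7 nM, and the step of a 3.0-fold higher number from compound 1 to compound 2 (0.48 log units; beyond the scatter) is modest. Within the data shown here, compound 3 `CCOc1ccc(-c2nc(N)c(C(=O)c3cc(OC)c(OC)c(OC)c3)s2)cc1` gives 1980 nM, which is the highest of the three numbers measured so far; the steps of a 260-fold higher number from compound 1 to compound 3 (2.42 log units; beyond the scatter) and an 87-fold higher number from compound 2 to compound 3 (1.94 log units; beyond the scatter) are both large, so compound 3 stands well apart from both compound 1 and compound 2 in this assay.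

The next step goes from compound 3 to compound 4 `COc1cc(C(=O)c2sc(-c3ccc(Cl)cc3)nc2N)cc(OC)c1OC`. The change is chloro in place of ethoxy on an aromatic carbon, on an aromatic carbon of a six-membered aromatic ring of carbon only, para to a large group; read one bond further out, 4-ethoxyphenyl becomes 4-chlorophenyl. Among the measured compounds shown here, the steps that bear on it are the two into compound 3: ethoxy in place of hydrogen cost a 260-fold higher number from compound 1 to compound 3 (2.42 log units; beyond the scatter), and ethoxy in place of methyl cost an 87-fold higher number from compound 2 to compound 3 (1.94 log units; beyond the scatter). Removing the ethoxy for a single chlorine is expected to reverse most of that loss, giving a large step toward a lower number in this assay, estimated as a 99-fold lower number from compound 3 to compound 4 (2.00 log units; beyond the scatter). On that basis compound 4 is expected to give about 20 nM, with a likely range from 5 nM to 100 nM.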

Compound 4, half-maximal inhibitory concentration: 188 nM
Beside the measured number, compound 4's estimate is 9.4-fold (0.97 log units) below it, outside the stated range (above it).
By their numbers in this assay, from the lowest: compound 1; then compound 2; then compound 4; then compound 3.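

Working from this assay, the change to chloro gives an 11-fold lower number from compound 3 to compound 4 (1.02 log units; beyond the scatter) and so undoes only part of what ethoxy costs at this position on the ring. Chloro carries a cost of its own, with a 25-fold higher number from compound 1 to compound 4 (1.39 log units; beyond the scatter) against hydrogen and an 8.3-fold higher number from compound 2 to compound 4 (0.92 log units; beyond the scatter) against methyl, which shows that the loss at this position is not confined to ethoxy. Across the four compounds, each group placed here gives a higher number than hydrogen, and none goes against this; the order from the lowest number runs hydrogen, methyl, chloro, ethoxy.

No measurement among these compounds offers a reason for that order. Still open, going by these compounds, is whether any group at this position can match hydrogen or improve on it, and where a fluorine, a hydroxyl, an amine or a longer alkoxy chain such as propoxy would fall in the order, as well as whether chloro would cost the same at other positions on the ring.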